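Working notes: from compound 3 to compound 4

A few compounds are considered here, and "the series" means these few. Any claim that something is new, unique, unknown or untested is made for them only; others in the source may bear on it.

Measured in a functional assay on A-375 cells (Homo sapiens) for cytotoxicity, read by MTT assay; a higher number here means a weaker inhibitor, a lower number a stronger inhibitor:
- compound 1 `C#CCOc1cc(/C=C/C(=O)c2ccc(OC)c3c2OC(C)(C)C=C3)ccc1OC`: > 10000 nM (a limit of the assay, not a number)
- compound 2 `COc1ccc(/C=C/C(=O)c2ccc(OC)c3c2OC(C)(C)C=C3)cc1OCCO`: 9600 nM
- compound 3 `COc1cccc(C(=O)Oc2cc(/C=C/C(=O)c3ccc(OC)c4c3OC(C)(C)C=C4)ccc2OC)c1`: 800 nM

Compound 3 has the lowest of the numbers obtained in this assay, and a 12-fold lower number from compound 2 to compound 3 (1.08 log units; beyond the scatter) is large and beyond the scatter. The comparison with the limit gives an at least 12-fold lower number from compound 1 to compound 3 (1.09 log units; beyond the scatter), also beyond the scatter. By contrast, an at least 1.0-fold lower number from compound 1 to compound 2 (0.01 log units; that floor lies within the scatter) stays within the scatter.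

Compound 4 `COc1ccc(/C=C/C(=O)c2ccc(OC)c3c2OC(C)(C)C=C3)cc1OC(=O)c1ccc(Br)cc1` differs from compound 3 only in the group on the carbonyl carbon: 4-bromophenyl in place of 3-methoxyphenyl on a carbonyl carbon. Thus 4-bromophenyl stands in place of 3-methoxyphenyl. Neither large step tests this exchange, since each one replaces the whole (3-methoxyphenyl)carbonyl group, and compound 4 keeps a carbonyl with a phenyl ring on that oxygen. The expectation is therefore that compound 4 stays close to compound 3, whose a 12-fold lower number from compound 2 to compound 3 (1.08 log units; beyond the scatter) is the nearest guide, with no step beyond the scatter. The expected step is a 1.3-fold higher number from compound 3 to compound 4 (0.10 log units; within the scatter). Compound 4 is estimated at 1000 nM, with an expected range of 300 nM to 3500 nM.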

Compound 4, half-maximal inhibitory concentration: 420 nM
Beside the measured number, compound 4's estimate is 2.4-fold (0.38 log units) above it; the measured number falls inside the stated range.
By their numbers in this assay, from the lowest: compounds 4 and 3 (each within the scatter of the next); then compound 2. At a limit, above all of these: compound 1.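

In this assay, 4-bromophenyl in place of 3-methoxyphenyl on the carbonyl carbon gives a 1.9-fold lower number from compound 3 to compound 4 (0.28 log units; within the scatter), so this position tolerates this exchange of aromatic groups without a step beyond the scatter. The large step away from 2-hydroxyethyl also recurs with a second carbonyl group, a 23-fold lower number from compound 2 to compound 4 (1.36 log units; beyond the scatter), and so is not confined to the (3-methoxyphenyl)carbonyl group. With a limit of the assay in place of a number, the remaining step reads only as a floor, an at least 23-fold lower number from compound 1 to compound 4 (1.37 log units; beyond the scatter): the limit of > 10000 nM in this assay, at which 1 of the 4 values shown sits.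

The two aromatic groups differ in both substituent and its location on the ring, so these two changes stay unseparated. From the compounds shown here alone, whether the aromatic ring on the carbonyl carbon is needed at all stays open, as would be tested by an unsubstituted phenyl, a saturated alkyl chain or a chain ending in an amine.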